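Nitrogen-rich side chain in place of isopropyl on the amide

The source may report more compounds than this note shows. Statements on the series, on what has been measured and on what is new or still open speak of the compounds shown alone.

Compound 1, `C[C@H](NC(=O)CN(c1nc(Cl)nc2[nH]cnc12)C1CC1)C(=O)OCc1ccccc1`, gives 64.3% in a functional assay on the whole organism (Tail, strain ICR) with Mus musculus as the target, in the tail flick test, with a stated time of 60 min, at a dose of 25 umol/kg by the oral route; on this read-out higher numbers stand for a stronger effect at the one dose given and lower numbers for a weaker effect.
Compound 2, `O=C(CN(c1nc(Cl)nc2[nH]cnc12)C1CC1)NCC(=O)OCc1ccccc1`, gives 41.9% in this assay.
Compound 3, `CC(C)[C@H](NC(=O)CN(c1nc(Cl)nc2[nH]cnc12)C1CC1)C(=O)OCc1ccccc1`, gives 55.5% in this assay.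

Three compounds share one core and differ only in the group on the saturated chain carbon bound to an amide-type nitrogen and a carbonyl carbon. Compound 3 stands second highest of the three, with compound 1 nearest, as the step of a number 8.8 percentage points lower from compound 1 to compound 3 (within the scatter) lies within the scatter, and compound 2 furthest, the step of a number 13.6 percentage points higher from compound 2 to compound 3 (beyond the scatter) being beyond it. The new compound 4, `N=C(N)NCCC[C@H](NC(=O)CN(c1nc(Cl)nc2[nH]cnc12)C1CC1)C(=O)OCc1ccccc1`, differs from compound 3 by a group of 7 heavy atoms (4 carbon, 3 nitrogen; no ring) in place of a group of 3 heavy atoms (3 carbon; no ring), on a saturated chain carbon bound to an amide-type nitrogen and a carbonyl carbon. The measured steps only swap hydrogen, methyl and isopropyl at this place; none brings in nitrogen or hydrogen-bond donors, so they bear on this change only loosely. Those steps were modest at most, and a change of similar modest size, in either direction, is the most that can be read from them. Compound 4 is therefore expected to give about 52% in this assay, within 28% to 76%, an estimated step of a number 3.5 percentage points lower from compound 3 to compound 4 (within the scatter) that is not expected to exceed the scatter.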

Compound 4, a percentage reported as activity, at one dose (the size of the read-out at that dose, not a potency): 30.6%
Estimate against measurement, compound 4: 21.4 percentage points above; low and high end bracket the measured number.
By their numbers in this assay, from the lowest: compound 4; then compound 2; then compounds 3 and 1 (each within the scatter of the next).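

In this assay, the group of 7 heavy atoms with its nitrogens and hydrogen-bond donors lowers the read-out well beyond the scatter, with a number 24.9 percentage points lower from compound 3 to compound 4 (beyond the scatter) and a number 33.7 percentage points lower from compound 1 to compound 4 (beyond the scatter). Whereas methyl and isopropyl both left the number above that of the hydrogen compound, this larger group falls below it, with a number 11.3 percentage points lower from compound 2 to compound 4 (beyond the scatter), so a substituent at this place does not in itself raise the read-out among these compounds. No measurement shown explains the fall.

A single nitrogen-bearing chain cannot separate the contribution of its length from that of its nitrogens. A plain straight carbon chain of similar length, or the same chain ending in a simple amine or a carboxylic acid, would be needed to tell these apart.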